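The source may hold more compounds than are shown below. What is called first, only, known or untested is meant among the compounds shown, and "the series" means these compounds.

Of the compounds shown here, two built on a shared core have been measured in an assay on microsomes for inhibition of acyl-CoA:cholesterol acyltransferase (Oryctolagus cuniculus); a higher number here means a weaker inhibitor, a lower number a stronger inhibitor. Compound 1 `CC(C)c1cccc(C(C)C)c1NC(=O)NCC1(c2ccc(C(F)(F)F)cc2)CCCC1` gives 66 nM. Compound 2 `COC(=O)c1ccc(C2(CNC(=O)Nc3c(C(C)C)cccc3C(C)C)CCCC2)cc1` carries a methoxycarbonyl group where compound 1 carries trifluoromethyl; in this assay compound 2 gives 360 nM. That step, a 5.5-fold higher number from compound 1 to compound 2 (0.74 log units; beyond the scatter), is the only one measured so far. Compound 2 therefore stands with the higher number of the two, and its nearest neighbour is compound 1, which sits lower by that same step.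

Compound 3 `CC(C)c1cccc(C(C)C)c1NC(=O)NCC1(c2cccc(C(=O)O)c2)CCCC1` has not yet been measured. It differs from compound 2 in one place: 3-carboxyphenyl in place of 4-(methoxycarbonyl)phenyl on a saturated ring carbon. For the measured compounds named here, an ester thus gives way to a carboxylic acid, and the group also sits differently on the ring; no measured step covers either of these changes directly. The step from compound 1 to compound 2 bears on it only loosely, showing that a change of the group on this ring can move the number by a modest amount. A modest move upward is expected here as well, so compound 3 is estimated at 1000 nM, between 300 nM and 4000 nM, which would be a step of a 2.8-fold higher number from compound 2 to compound 3 (0.44 log units; beyond the scatter) in this assay.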

Compound 3, half-maximal inhibitory concentration: 620 nM
For compound 3 the middle estimate is 1.6-fold (0.21 log units) above the measured one; the measured number falls inside the stated range.
By their numbers in this assay, from the lowest: compound 1; then compounds 2 and 3 (each within the scatter of the next).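

In this assay, putting 3-carboxyphenyl in place of 4-(methoxycarbonyl)phenyl on a saturated ring carbon gives a 1.7-fold higher number from compound 2 to compound 3 (0.24 log units; within the scatter), so this assay does not tell these two compounds apart, even though the group and its place on the ring both differ between them. Set against the trifluoromethyl compound, the same 3-carboxyphenyl group gives a 9.4-fold higher number from compound 1 to compound 3 (0.97 log units; beyond the scatter), which is beyond the scatter and larger than the step to the ester, so compound 1 remains the strongest inhibitor of the three and both oxygen-bearing groups sit clearly apart from it. Nothing available here accounts for either step.

On these data alone, the change from compound 2 to compound 3 alters the group and its place on the ring in a single move, so it remains open whether each alteration alone would have little effect or whether two larger effects offset each other. As far as these compounds go, it also remains open how other groups on this ring, such as a nitrile, a primary amide or an amine, would compare with trifluoromethyl.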